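A few compounds are considered here, and "the series" means these few. Any claim that something is new, unique, unknown or untested is made for them only; others in the source may bear on it.

Measured compounds:
compound 1, `Cc1cccc(C)c1-c1c(N)c(C(=O)c2ccc(F)cc2F)cc[n+]1[O-]`, 40 ug/mL
compound 2, `Cc1cc(O)ccc1-c1c(N)c(C(=O)c2ccc(F)cc2F)cc[n+]1[O-]`, 44 ug/mL

In a physicochemical assay for solubility, at pH 0.1 (on this read-out lower numbers stand for lower solubility and higher numbers for higher solubility), compound 2 gives 44 ug/mL, the higher of the two numbers in hand, though its nearest neighbour, compound 1, lies within the scatter of it with 40 ug/mL. Compound 3, `Nc1c(C(=O)c2ccc(F)cc2F)cc[n+]([O-])c1-c1ccccc1Cl`, has not yet been measured in this assay. It differs from compound 2 in one place: 2-chlorophenyl in place of 4-hydroxy-2-methylphenyl on an aromatic carbon. Going by the values given here, the one step recorded so far is the nearest guide: a 1.1-fold higher number from compound 1 to compound 2 (0.04 log units; within the scatter), which shows that exchanging the 2,6-dimethylphenyl for the 4-hydroxy-2-methylphenyl left this read-out unchanged beyond the scatter. Among the compounds with values here, that step shares the site of change with the step to compound 3, but not the entering group, and no measured pair shows a 2-chlorophenyl at this position. On that basis the expected change is small: compound 3 is estimated at 35 ug/mL, with a range from 15 ug/mL to 90 ug/mL, which means an expected step of a 1.3-fold lower number from compound 2 to compound 3 (0.10 log units; within the scatter), not beyond the scatter.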

Compound 3, solubility: 66 ug/mL
For compound 3 the middle estimate is 1.9-fold (0.28 log units) below the measured one; the measured number falls inside the stated range.
By their numbers in this assay, from the lowest: compounds 1, 2 and 3 (each within the scatter of the next).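

At this position, on an aromatic carbon next to the ring nitrogen, this assay now gives a 1.5-fold higher number from compound 2 to compound 3 (0.18 log units; within the scatter) and a 1.7-fold higher number from compound 1 to compound 3 (0.22 log units; within the scatter) for the entry of the 2-chlorophenyl group, so a third group at this site also leaves every step within the scatter. Compound 3 has no hydrogen-bond donor or acceptor in this group, yet its number lies within the scatter of that of compound 2, which carries a hydroxyl there, and the earlier pair alone could not show this. Nothing in hand offers a measured explanation for how closely these numbers lie together.

On these data alone, all three compounds carry a six-membered aromatic ring of carbon only at this position, so it remains open whether a group of another kind, such as an aliphatic amine, a carboxylic acid or a longer chain, would give a step beyond the scatter. Nor do the compounds show how this assay responds to a change elsewhere on the shared core, such as a methylamino group in place of the amino group.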